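Chain extension tried on the second core

The compounds below may be only part of what the source reports. "The series", "measured", "known", "first", "only" and "open" are said of these compounds alone.

Compound 1 `Cc1ccc2oc(-c3ccc(NC(=O)CN4CCN(CCN(C)C)CC4)cc3)nc2c1` is paired with compound 3 `Cc1ccc2oc(-c3ccc(NC(=O)CN4CCN(CCCN(C)C)CC4)cc3)nc2c1`, which carries (dimethylamino)methyl in place of dimethylamino on a saturated chain carbon, two bonds along the chain from an amine nitrogen in a ring. In a functional assay on HT-29 cells (Homo sapiens) for cytotoxicity, read by MTT assay, with a stated time of 24 h (on this read-out lower numbers stand for stronger inhibition and higher numbers for weaker inhibition), compound 1 gives 1790 nM, while compound 3 gives 3890 nM, so this change brought a 2.2-fold higher number from compound 1 to compound 3 (0.34 log units; beyond the scatter). Compound 2 `Cc1cc(-c2nc3cc(Cl)ccc3o2)ccc1NC(=O)CN1CCN(CCN(C)C)CC1` rests on a different core; how its core differs from that of compound 1 is not broken down here. In this assay compound 2 gives 13200 nM, the highest number among the three measured compounds. Compound 4 `Cc1cc(-c2nc3cc(Cl)ccc3o2)ccc1NC(=O)CN1CCN(CCCN(C)C)CC1` stands to compound 2 as compound 3 stands to compound 1: it carries (dimethylamino)methyl in place of dimethylamino on a saturated chain carbon, two bonds along the chain from an amine nitrogen in a ring, at a place described in the same words, so it is the same change made on the other core. The expectation for compound 4 rests on the one measured example of this change, the step from compound 1 to compound 3 shown as a 2.2-fold higher number from compound 1 to compound 3 (0.34 log units; beyond the scatter), and the same direction and about the same size are expected here, as a 2.1-fold higher number from compound 2 to compound 4 (0.33 log units; beyond the scatter). Starting from the measured number of compound 2, the estimate for compound 4 in this assay is 28000 nM, with a range from 12000 nM to 65000 nM that allows for a single precedent taken from a different core.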

Compound 4, half-maximal inhibitory concentration: 9150 nM
Compound 4: the middle estimate sits 3.1-fold (0.49 log units) above what was measured; the measured number lies below the stated range.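

On the core of compound 2, putting (dimethylamino)methyl in place of dimethylamino on the saturated chain carbon gave a step that does not stand out from the scatter in this assay, which reads as a 1.4-fold lower number from compound 2 to compound 4 (0.16 log units; within the scatter), so compound 2 and compound 4 cannot be told apart there. Set beside the step on the core of compound 1, the same change did not carry over from one core to the other in this assay: the same change on two cores in this assay, a 2.2-fold higher number (0.34 log units; beyond the scatter) from compound 1 to compound 3 and a 1.4-fold lower number (0.16 log units; within the scatter) from compound 2 to compound 4, 3.1-fold (0.50 log units) apart, beyond the scatter of two such steps. Among the compounds shown here, this shows that the step seen on one core cannot be applied as a fixed increment to the other, but with only two pairs it gives no general rule and does not show which part of the core difference matters.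

The compounds shown leave open how a longer chain ending in dimethylamino would behave on either core. They also leave open whether a diethylamino group or a primary amine at the chain end would follow the core of compound 1 or that of compound 2.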